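Swapping phenyl for sec-butyl on a hydantoin-type scaffold

The compounds below may be only part of what the source reports. "The series", "measured", "known", "first", "only" and "open" are said of these compounds alone.

Compound 1, `CCC(C)C(NC(=O)n1nnc2ccccc21)C(=O)NC(c1ccccc1)c1ccccc1`: 80 ug/mL
Compound 2, `O=C1NC(c2ccccc2)C(=O)N1C1CCCC1`: >= 20 ug/mL
Compound 3, `O=C1NC(c2ccccc2)C(=O)N1Cc1ccccc1`: 100 ug/mL

In a functional assay on HEL cells (Homo sapiens) for cytotoxicity (a lower number here means that less compound is tolerated, a higher number that more compound is tolerated), compound 3 gives 100 ug/mL and compound 1 gives 80 ug/mL; the two numbers lie within the usual scatter of each other. For compound 2 the value in this assay is a limit of the assay, not a number. Compound 4, `CCC(C)C1NC(=O)N(Cc2ccccc2)C1=O`, differs from compound 3 by sec-butyl in place of phenyl on a saturated ring carbon. Within the data shown here, no measured pair in this set shows what such a change does, so the expectation rests on the narrow spread of the numbers seen so far: the step of no change at the digits printed from compound 3 to compound 4 (within the scatter) is expected to be none beyond the scatter. Compound 4 is estimated at 100 ug/mL in this assay, within a range from 40 ug/mL to 250 ug/mL.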

Compound 4, minimum cytotoxic concentration: 100 ug/mL
Estimate against measurement, compound 4: no gap at the digits printed; measured number inside the range.
By their numbers in this assay, from the lowest: compounds 1, 3 and 4 (each within the scatter of the next).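

In this assay, among these compounds, sec-butyl in place of phenyl on the saturated ring carbon gives no change at the digits printed from compound 3 to compound 4 (within the scatter), the first step that can be read at this position. At this place, then, an open sec-butyl group can stand where the six-membered aromatic ring stood, with no shift beyond the scatter. Nothing shown here gives a cause for this outcome. From the compounds shown here alone, whether an amine, a carboxylic acid or a longer chain on the same ring carbon would also leave the number unmoved remains open. So does whether this swap holds with another group on the ring nitrogen.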